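Cyclohexyl on the ring nitrogen of a nitrile inhibitor

A few compounds are considered here, and "the series" means these few. Any claim that something is new, unique, unknown or untested is made for them only; others in the source may bear on it.

Compound 3 `N#C[C@@]1(NC(=O)[C@@H](CC(=O)N2CCOCC2)CC2CCCCC2)CCNC1` is the weakest of the three measured compounds in an assay on isolated protein for inhibition of cathepsin S (Homo sapiens) (on this read-out lower numbers stand for stronger inhibition and higher numbers for weaker inhibition), where compound 3 gives 141 nM. Compound 1 `CC(C)N1CC[C@@](C#N)(NC(=O)[C@@H](CC(=O)N2CCOCC2)CC2CCCCC2)C1` gives 66 nM in this assay, and compound 2 `N#C[C@@]1(NC(=O)[C@@H](CC(=O)N2CCOCC2)CC2CCc3ccccc3C2)CCN(C2CCCCC2)C1` gives 1.9 nM. The unmeasured compound 4 `N#C[C@@]1(NC(=O)[C@@H](CC(=O)N2CCOCC2)CC2CCCCC2)CCN(C2CCCCC2)C1` differs from compound 3 in one place: cyclohexyl in place of hydrogen on an amine nitrogen in a ring. Among the compounds with values here, one measured step bears on this change, running the other way: the step of a 2.1-fold higher number from compound 1 to compound 3 (0.33 log units; beyond the scatter). Going from hydrogen back to an alkyl group on that nitrogen should therefore lower the number, and cyclohexyl is a larger group than isopropyl, so a step of at least the size seen there is expected. Compound 2, which also carries cyclohexyl on an amine nitrogen in a ring but differs elsewhere, shows a much lower number than compound 3 and marks a plausible floor. Compound 4 is therefore expected to show a step of a 7.1-fold lower number from compound 3 to compound 4 (0.85 log units; beyond the scatter) in this assay. The estimate for compound 4 is 20 nM, with a range from 5 nM to 60 nM.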

Compound 4, half-maximal inhibitory concentration: 23 nM
Beside the measured number, compound 4's estimate is 1.2-fold (0.06 log units) below it; the measured number falls inside the stated range.
By their numbers in this assay, from the lowest: compound 2; then compound 4; then compound 1; then compound 3.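

In this assay, within the data shown here, cyclohexyl on the amine nitrogen in a ring gives a 6.1-fold lower number from compound 3 to compound 4 (0.79 log units; beyond the scatter) in a direct comparison, which the earlier compounds could only suggest. Cyclohexyl also goes beyond isopropyl at this position, with a 2.9-fold lower number from compound 1 to compound 4 (0.46 log units; beyond the scatter) on the same core, so across these three compounds the number falls from hydrogen to isopropyl to cyclohexyl. The change on the saturated chain carbon can now be read on its own as well: a 12-fold higher number from compound 2 to compound 4 (1.08 log units; beyond the scatter) when cyclohexyl replaces 1,2,3,4-tetrahydronaphthalen-2-yl, so cyclohexyl on the nitrogen does not by itself reach the number of compound 2. Nothing available explains these steps. As far as these compounds go, it remains open whether a phenyl or benzyl group on that nitrogen would extend the series, and whether the steps at the two places would add up on other nitrogen groups.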